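From methoxy to nitro: what should change?

A few compounds are considered here, and "the series" means these few. Any claim that something is new, unique, unknown or untested is made for them only; others in the source may bear on it.

Compound 1 `C/C(=C\c1ccccc1)C(=O)/C=C/c1ccccc1` gives 33600 nM
Compound 2 `COc1ccc(/C=C(\C)C(=O)/C=C/c2ccccc2)cc1` gives 44000 nM

These values come from an ADME assay on LLC-MK2 cells (Macaca mulatta) for cytotoxicity, read by MTT assay, with a stated time of 48 h; a lower number here means that less compound is tolerated, a higher number that more compound is tolerated. Among the measured compounds shown here, compound 2 stands within the scatter of compound 1, the only other measured compound. Compound 3 `C/C(=C\c1ccc([N+](=O)[O-])cc1)C(=O)/C=C/c1ccccc1` has not yet been measured. Compared with compound 2, it has nitro in place of methoxy on an aromatic carbon, para to a large group (nitro in place of methoxy on an aromatic carbon). For the measured compounds named here, one measured step bears on this change: methoxy in place of hydrogen on an aromatic carbon (a 1.3-fold higher number from compound 1 to compound 2 (0.12 log units; within the scatter)), which stayed within the scatter. Going by the values given here, no measured compound carries nitro, so this guide is weak. No step beyond the scatter is expected in this assay for now. The expected step is a 1.3-fold lower number from compound 2 to compound 3 (0.12 log units; within the scatter) and remains only an estimate. The estimate for compound 3 is 33000 nM (expected range 13000 nM to 75000 nM).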

Compound 3, half-maximal cytotoxic concentration: 264000 nM
Estimate against measurement, compound 3: 8.0-fold (0.90 log units) below; the measured number lies above the stated range.
By their numbers in this assay, from the lowest: compounds 1 and 2 (each within the scatter of the next); then compound 3.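

In this assay, the aromatic carbon para to a large group is not indifferent to what it carries: nitro in place of methoxy there gives a 6.0-fold higher number from compound 2 to compound 3 (0.78 log units; beyond the scatter), and nitro in place of hydrogen gives a 7.9-fold higher number from compound 1 to compound 3 (0.90 log units; beyond the scatter). Methoxy in place of hydrogen at this same carbon had stayed within the scatter, so the earlier pair gave no sign that a change here could matter, whereas compound 3 now stands clearly as the best tolerated of the three. Nothing available explains why nitro behaves so differently from methoxy and hydrogen. The compounds shown leave open whether this rise belongs to nitro alone or would also appear with a nitrile, a trifluoromethyl or an amine at this carbon. They also leave open whether nitro elsewhere on the shared core would do the same.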